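Hexylsulfanyl to butoxy on the shared core

The source may report more compounds than this note shows. Statements on the series, on what has been measured and on what is new or still open speak of the compounds shown alone.

Values in an ADME assay on HFF cells (Homo sapiens) for cytotoxicity, with a stated time of 8 days (on this read-out higher numbers stand for lower toxicity in this test and lower numbers for higher toxicity in this test), so far
Compound 1 `C=CCOc1nc(N)nc2c1ncn2/C=C1/CC1(CO)CO` gives > 300000 nM as a limit
Compound 2 `CCCCCCSc1nc(N)nc2c1ncn2/C=C1/CC1(CO)CO` gives > 300000 nM as a limit

Compound 2 has no number, only the limit > 300000 nM as its reading. The next member, compound 3 `CCCCOc1nc(N)nc2c1ncn2/C=C1/CC1(CO)CO`, carries this change: butoxy in place of hexylsulfanyl on an aromatic carbon with butoxy in place of hexylsulfanyl on an aromatic carbon. For the measured compounds named here, the one measured step that bears on it is a step that the two limits leave unreadable from compound 1 to compound 2 with hexylsulfanyl in place of allyloxy, and its size cannot be read. The evidence on that step is the limit of > 300000 nM in this assay, at which 2 of the 2 values shown sit, and it gives no size for any change at this carbon. Going by a step that the two limits leave unreadable from compound 1 to compound 2 as the sole guide, no step beyond the scatter is expected in this assay in either direction. The estimated step is a number no higher from compound 2 to compound 3 (the limit leaves the size open) and no more than that is expected. Compound 3 is estimated at 300000 nM with an expected range from 120000 nM to 500000 nM and a further limit reading is the likeliest outcome.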

Compound 3, half-maximal cytotoxic concentration: > 300000 nM
Compound 3: only a limit was reported; the forecaster's own chance of this, stated with the estimate: 85%; the middle value lies on the limit itself.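

In this assay compound 3 gives > 300000 nM, which is a limit, so no new step can be read from compound 1 or compound 2 to compound 3: the limit of > 300000 nM in this assay, at which 3 of the 3 values shown sit.

The compounds shown leave open whether the allyloxy, hexylsulfanyl and butoxy groups on the shared core differ at all in this assay.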